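Methyl Extended to Ethyl on the Shared Core

The compounds below may be only part of what the source reports. "The series", "measured", "known", "first", "only" and "open" are said of these compounds alone.

For the measured compounds named here, compound 2 `CO/N=C1\C[C@@H](c2ccccc2)N[C@@H](c2ccccc2)[C@@H]1C` gives 113000 nM in a functional assay on HeLa cells (Homo sapiens) for inhibition, read by MTT assay, with a stated time of 24 h (on this read-out lower numbers stand for stronger inhibition and higher numbers for weaker inhibition), the second highest of the three numbers known here. Its nearest neighbour, compound 1 `CO/N=C1\C[C@@H](c2ccccc2)N[C@@H](c2ccccc2)C1`, gives 121000 nM in this assay; the furthest, compound 3 `CO/N=C1\C[C@@H](c2ccc(Cl)cc2)N[C@@H](c2ccc(Cl)cc2)[C@@H]1C`, gives 49000 nM in this assay, and since compound 3 differs from compound 2 in two places, only the values themselves are noted. Compound 4 `CC[C@@H]1/C(=N/OC)C[C@@H](c2ccccc2)N[C@H]1c1ccccc1` differs from compound 2 by methyl in place of hydrogen on a saturated chain carbon bound to a saturated ring carbon. Going by the values given here, the one step that bears on this change is a 1.1-fold lower number from compound 1 to compound 2 (0.03 log units; within the scatter), which introduced the very methyl that compound 4 now lengthens. Compound 4 is therefore expected to show no step beyond the scatter, a 1.0-fold lower number from compound 2 to compound 4 (0.01 log units; within the scatter). Compound 4 is estimated at 110000 nM, with a range from 50000 nM to 250000 nM.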

Compound 4, half-maximal inhibitory concentration: 57300 nM
Estimate against measurement, compound 4: 1.9-fold (0.28 log units) above, within the range that was stated.
By their numbers in this assay, from the lowest: compounds 3, 4, 2 and 1 (each within the scatter of the next, the first and the last beyond it).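

In this assay the change from methyl to ethyl stays within the scatter (a 2.0-fold lower number from compound 2 to compound 4 (0.29 log units; within the scatter)). Counted from hydrogen, however, ethyl on this saturated ring carbon passes the scatter, though only modestly (a 2.1-fold lower number from compound 1 to compound 4 (0.32 log units; beyond the scatter)), which methyl alone did not do (a 1.1-fold lower number from compound 1 to compound 2 (0.03 log units; within the scatter)). Nothing measured here accounts for this small step. On these data alone, whether a propyl chain or a chain ending in an amine at this place would extend the step remains open. So does whether ethyl would give a similar step on the core of compound 3.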